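Compound 3 to compound 4 on the carbonyl carbon

The source may report more compounds than this note shows. Statements on the series, on what has been measured and on what is new or still open speak of the compounds shown alone.

In a functional assay on MDA-MB-231 cells (Homo sapiens) for cytotoxicity, read by MTT assay, with a stated time of 48 h (a higher number here means a weaker inhibitor, a lower number a stronger inhibitor), compound 1 `O=C(NCCCCC(c1ccc(F)cc1)c1ccc(F)cc1)Nc1ccc([N+](=O)[O-])cc1` gives 6470 nM and compound 3 `Nc1cc(NC(=O)NCCCCC(c2ccc(F)cc2)c2ccc(F)cc2)ccc1Cl` gives 9240 nM as values within the scatter of each other. Compound 2 `Cc1cccc(NC(=O)NCCCCC(c2ccc(F)cc2)c2ccc(F)cc2)c1` gives > 20000 nM as a limit and not a number. Compound 4 `O=C(NCCCCC(c1ccc(F)cc1)c1ccc(F)cc1)c1ccc(Cl)c(C(F)(F)F)c1` carries 4-chloro-3-(trifluoromethyl)phenyl in place of (3-amino-4-chlorophenyl)amino on a carbonyl carbon with 4-chloro-3-(trifluoromethyl)phenyl in place of (3-amino-4-chlorophenyl)amino on a carbonyl carbon as the counted change. The measured steps all exchange groups on an amide-type nitrogen and so bear only loosely on this change: a 1.4-fold higher number from compound 1 to compound 3 (0.15 log units; within the scatter) stays within the scatter, while an at least 3.0-fold higher number from compound 1 to compound 2 (0.49 log units; beyond the scatter) and an at least 2.1-fold lower number from compound 2 to compound 3 (0.33 log units; beyond the scatter) go beyond it and both involve the limit of compound 2. Starting from compound 3 at 9240 nM no step beyond the scatter is expected in this assay and no direction is favoured. The expected step is a 1.2-fold lower number from compound 3 to compound 4 (0.06 log units; within the scatter) as an estimate. For compound 4 the estimated value is 8000 nM with an expected range from 3000 nM to 20000 nM in this estimate.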

Compound 4, half-maximal inhibitory concentration: 11700 nM
The estimate for compound 4 lay 1.5-fold (0.17 log units) below the measured number; low and high end bracket the measured number.
By their numbers in this assay, from the lowest: compounds 1, 3 and 4 (each within the scatter of the next). At a limit, above all of these: compound 2.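

In this assay, the carbonyl carbon carries 4-chloro-3-(trifluoromethyl)phenyl in place of an arylamino group without a step beyond the scatter: a 1.3-fold higher number from compound 3 to compound 4 (0.10 log units; within the scatter) and a 1.8-fold higher number from compound 1 to compound 4 (0.26 log units; within the scatter). So the amino link on the carbonyl carbon, absent in compound 4, is not needed to stay within the scatter of compound 1 and compound 3. Against compound 2 the reading is weaker, with an at least 1.7-fold lower number from compound 2 to compound 4 (0.23 log units; that floor lies within the scatter), and this step rests on a limit and not a number: the limit of > 20000 nM in this assay, at which 1 of the 4 values shown sits.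

Open, from the compounds shown here alone, is what (4-chloro-3-(trifluoromethyl)phenyl)amino on the same carbonyl carbon would give, which would separate the link from the ring substituents. Also open, going by these compounds, is whether a carboxylic acid or a basic amine on the ring would move the number beyond the scatter.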